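This account rests on a few compounds, and the source may have more. Where it says the series, first, only, none or still open, it means among the compounds named here.

Compound 1 `Cc1nc(-c2ccc(C(F)(F)F)cc2)sc1CNc1ccc(CCC(=O)O)cc1`: 108%
Compound 2 `O=C(O)COc1ccc(NCc2cccc(Oc3ccccc3)c2)cc1`: 84%
Compound 3 `CC(C)(Oc1ccc(NCc2cccc(Oc3ccccc3)c2)cc1)C(=O)O`: 14%

The three measured compounds were tested in a functional assay on CHO cells for agonist activity at Free fatty acid receptor 1 (Homo sapiens), read by a luciferase reporter; a higher number here means a larger maximal response, a lower number a smaller maximal response. Compound 1 stands highest of the three, and its gaps to compound 2 and to compound 3 both lie beyond the usual scatter. Among the compounds with values here, the only single-point step among them is a number 70 percentage points lower from compound 2 to compound 3 (beyond the scatter), a large loss of response that came from altering the acid-bearing end of the molecule.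

Compound 4 `Cc1nc(-c2ccc(C(F)(F)F)cc2)sc1CNc1ccc([C@H]2C[C@@H]2C(=O)NO)cc1` differs from compound 1 in one place: 2-(hydroxycarbamoyl)cyclopropyl in place of 2-carboxyethyl on an aromatic carbon. This is again a change at the acid-bearing end, and it is a deeper one than the step from compound 2 to compound 3, since the acid itself is exchanged for a hydroxycarbamoyl group on a three-membered ring. Within the data shown here, only that one step bears on the question, so the expectation rests on little, but its direction is downward. Compound 4 is therefore expected to reach a smaller maximal response, with an estimated step of a number 58 percentage points lower from compound 1 to compound 4 (beyond the scatter). The estimate for compound 4 is 50%, with a range from 10% to 95%.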

Compound 4, largest response reached (reported as percent of maximum), in percent of the reference or control that the assay uses: 78%
Estimate against measurement, compound 4: 28 percentage points below, and the stated range covers the measured number.
By their numbers in this assay, from the lowest: compound 3; then compounds 4 and 2 (each within the scatter of the next); then compound 1.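

In this assay, putting 2-(hydroxycarbamoyl)cyclopropyl in place of 2-carboxyethyl on an aromatic carbon para to a large group gives a number 30 percentage points lower from compound 1 to compound 4 (beyond the scatter) as a modest but real loss. The earlier compounds shown here all carry a carboxylic acid, so they could not show what compound 4 shows: with no carboxylic acid at this position, compound 4 still reaches 78% and keeps a substantial maximal response. No measurement here explains why the response falls by this amount.

The cyclopropyl ring and the hydroxycarbamoyl group enter together, so their separate contributions stay unresolved. A cyclopropyl ring bearing a carboxylic acid, or a hydroxycarbamoyl group on a plain two-carbon chain, would tell them apart, and the mirror-image cyclopropyl form would show whether the two stereocentres matter.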